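The compounds below may be only part of what the source reports. "The series", "measured", "known", "first", "only" and "open" are said of these compounds alone.

Measured so far:
compound 1, `COc1cccc(Cc2cc(C(C)C)nn(CC(=O)Nc3ccc(Br)cc3)c2=O)c1`: 17400 nM
compound 2, `COc1ccc(Cc2cc(-c3cccs3)nn(CC(=O)Nc3ccc(Br)cc3)c2=O)cc1`: > 50000 nM

The account concerns two measured compounds and one that has not yet been tested. In an assay on HL-60 cells for agonist activity at N-formyl peptide receptor 3 (Homo sapiens), read by calcium flux (a higher number here means that more compound is needed for the effect, a lower number that less compound is needed), compound 1 gives 17400 nM. For compound 2 the result is only a limit of the assay and not a number: > 50000 nM. Compound 2 therefore stands at the upper edge of what is shown, as noted in the limit of > 50000 nM in this assay, at which 1 of the 2 values shown sits, and no measured step between compounds 1 and 2 is given, since the two structures differ in more than one place.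

The step now under consideration leads from compound 2 to compound 3, `COc1ccc(Cc2cc(Cc3ccccc3)nn(CC(=O)Nc3ccc(Br)cc3)c2=O)cc1`. The change is benzyl in place of thiophen-2-yl on an aromatic carbon. Among the measured compounds shown here, no measured step of this kind is available, so the expectation rests on the position of compound 2 alone. The author expects no step beyond the scatter in this assay, with a fair chance that this assay again reports only a limit. Compound 3 is estimated at 45000 nM, within a range of 12000 nM to 150000 nM, which would mean an expected step of an at least 1.1-fold lower number from compound 2 to compound 3 (0.04 log units; that floor lies within the scatter).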

Compound 3, half-maximal effective concentration: > 50000 nM
Compound 3: only a limit was reported (the forecaster's own chance of this, stated with the estimate: 50%); at least 1.1-fold (0.04 log units) between middle value and limit.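

In this assay compound 3 gives > 50000 nM, which is a limit of the assay and not a number. Among the compounds shown here, compound 2 also stands at a limit, so no step between compound 2 and compound 3 can be read. The compounds shown leave open whether benzyl in place of thiophen-2-yl on an aromatic carbon changes the result in this assay at all.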